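Chloro for hydrogen on the phenyl: compound 3

A few compounds are considered here, and "the series" means these few. Any claim that something is new, unique, unknown or untested is made for them only; others in the source may bear on it.

Measured so far:
Compound 1 `COc1cccc(C(=O)N(C)/N=C/c2ccc(OC)c(OC)c2)c1` — in a functional assay on the whole organism (strain A/J) for inhibition, with Mus musculus as the target, with stated times of 1 h and 18 h, at a dose of 100 umol/kg by the oral route (a higher number here means more inhibition at the dose given (going by the name of the read-out), a lower number less inhibition), compound 1 gives 70%.
Compound 2 `COc1ccc(/C=N/N(C)C(=O)c2ccccc2)cc1OC` — in this assay compound 2 gives 58%.

Compound 2 stands lowest of the two numbers; the step of a number 12 percentage points lower from compound 1 to compound 2 (beyond the scatter) is the only one measured, a hydrogen in place of methoxy on an aromatic carbon. Compound 3 `COc1ccc(/C=N/N(C)C(=O)c2ccc(Cl)cc2)cc1OC` differs from compound 2 by chloro in place of hydrogen on an aromatic carbon. Going by the values given here, no measured step exchanges hydrogen for chloro, so the one step, modest and beyond the scatter, gives only a loose guide. A small step up or none beyond the scatter is expected, a number 4 percentage points higher from compound 2 to compound 3 (within the scatter). Compound 3 is expected to give 62%, with a range from 45% to 78%.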

Compound 3, a percentage reported as inhibition, in the whole organism at one dose (the size of the read-out at that dose, not a potency): 33%
For compound 3 the middle estimate is 29 percentage points above the measured one, outside the stated range (below it).
By their numbers in this assay, from the lowest: compound 3; then compound 2; then compound 1.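

Chloro on the phenyl, para to a large group, gives a number 25 percentage points lower from compound 2 to compound 3 (beyond the scatter) in this assay, so the unsubstituted phenyl of compound 2 now sits between two substituted rings: compound 1 above it and compound 3 below it. A substituent on this ring can therefore move the inhibition either way, and a number 37 percentage points lower from compound 1 to compound 3 (beyond the scatter) shows how wide that span is. Nothing at hand gives a reason for the loss with chloro.

Because compound 1 and compound 3 differ in both group and place, these effects cannot be separated. Going by these compounds, whether the loss is specific to chloro remains open, as would be tested by a methoxy, an amine or a carboxylic acid at the same place.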